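Hydroxymethyl added to the fused ring of compound 2

The compounds below may be only part of what the source reports. "The series", "measured", "known", "first", "only" and "open" are said of these compounds alone.

Of the compounds shown here, two have been tested in an assay on isolated protein for inhibition of ubiquitin carboxyl-terminal hydrolase 47 (Homo sapiens) (on this read-out higher numbers stand for weaker inhibition and lower numbers for stronger inhibition), and neither has given a number. Compound 1 `Nc1cc(-c2cc(Cl)cc3c2OC(C(=O)N2CCNCC2)C3)ccn1` carries an aminopyridine on the shared core; in this assay compound 1 gives only a limit, > 80000 nM. Compound 2 `O=C([C@H]1Cc2cc(Cl)cc(-c3ccnc4ccsc34)c2O1)N1CCNCC1` carries a fused bicyclic aryl instead; in this assay compound 2 also gives only a limit, > 40000 nM. Within the data shown here, both values are limits, so no step between compound 1 and compound 2 can be measured, and compound 2 cannot be placed relative to compound 1 beyond saying that both sit at the edge of what the assay reports.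

Compound 3 `O=C([C@H]1Cc2cc(Cl)cc(-c3ccnc4cc(CO)sc34)c2O1)N1CCNCC1` differs from compound 2 in one place: hydroxymethyl in place of hydrogen on an aromatic carbon. The group enters on an aromatic carbon of the five-membered aromatic ring next to the ring sulfur.

Among the measured compounds shown here, with no measured step to lean on, the expected step from compound 2 to compound 3, a step that the limit leaves unreadable from compound 2 to compound 3, is small and within the scatter, in no clear direction. Compound 3 is therefore expected to give about 60000 nM, in the range 15000 nM to 200000 nM, most likely reported again as a limit.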

Compound 3, half-maximal inhibitory concentration: > 40000 nM
Compound 3: no number, only a limit; the forecaster's own chance of this, stated with the estimate: 70%; the middle value lies beyond the limit too.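

In this assay, among these compounds, compound 3 and compound 2 both give only limits, so no step between them can be read. The compounds shown leave open whether hydroxymethyl in place of hydrogen on an aromatic carbon changes inhibition in this assay at all, and in which direction, as all values shown are limits: the limit of > 40000 nM in this assay, at which 2 of the 3 values shown sit.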